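Swapping 4-phenylphenyl for 3-aminophenyl on the shared core

A few compounds are considered here, and "the series" means these few. Any claim that something is new, unique, unknown or untested is made for them only; others in the source may bear on it.

Measured in a toxicity assay on NIH3T3 cells (Mus musculus) for cytotoxicity, read by resazurin assay; a higher number here means that more compound is needed for the effect, a lower number that less compound is needed:
- Compound 1 `COC(=O)c1ccc(NCc2cncn2Cc2ccc(Cl)cc2)cc1-c1ccccc1` gives 25000 nM
- Compound 2 `COC(=O)c1ccc(NCc2cncn2Cc2cccc(C)c2)cc1-c1ccccc1` gives > 10000 nM (a limit)
- Compound 3 `COC(=O)c1ccc(NCc2cncn2Cc2ccc(-c3ccccc3)cc2)cc1-c1ccccc1` gives > 1000 nM (a limit)

Compound 3 has no exact number in this assay. Its entry of > 1000 nM is a limit and not a measured value. The entry for compound 2, > 10000 nM, is also a limit.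

Compound 4 `COC(=O)c1ccc(NCc2cncn2Cc2cccc(N)c2)cc1-c1ccccc1` carries 3-aminophenyl in place of 4-phenylphenyl on a saturated chain carbon bound to an aromatic nitrogen.

Going by the values given here, three measured steps concern this same group: a step that the limit leaves unreadable from compound 1 to compound 2, a step that the limit leaves unreadable from compound 1 to compound 3 and a step that the two limits leave unreadable from compound 2 to compound 3. None of them has a readable size, and none gives a measured direction for the new change. Among the compounds with values here, the one exact number is that of compound 1 at 25000 nM, and the expectation for this assay rests on that value. The expected step is a step that the limit leaves unreadable from compound 3 to compound 4, an estimate measured against a limit and so only loosely sized. For compound 4 the expected value is about 20000 nM, with an estimated range from 6000 nM to 60000 nM.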

Compound 4, half-maximal effective concentration: > 10000 nM
Compound 4: only a limit was reported; the forecaster's own chance of this, stated with the estimate: 45%; the middle value lies beyond the limit too.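

In this assay, compound 4 gives > 10000 nM, which is a limit and not an exact number. The steps linking compound 4 to compound 1, compound 2 and compound 3 therefore cannot be read. The compounds shown leave open whether swapping among 4-chlorophenyl, 3-methylphenyl, 4-phenylphenyl and 3-aminophenyl changes the value in this assay at all.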